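The source may report more compounds than this note shows. Statements on the series, on what has been measured and on what is new or still open speak of the compounds shown alone.

Measured so far:
Compound 1, `C=CC(=O)Nc1ccc(Cn2nc(-c3ccc(Oc4ccccc4)cc3)cc2C(=O)O)cc1`: > 60000 nM (a limit)
Compound 2, `C/C=C/C(=O)Nc1ccc(Cn2nc(-c3ccc(Oc4ccccc4)cc3)cc2C(=O)O)cc1`: > 60000 nM (a limit)
Compound 3, `C/C=C/C(=O)Nc1cccc(Cn2nc(-c3ccc(Oc4ccccc4)cc3)cc2C(=O)OCC)c1`: 8900 nM

All three were tested in a functional assay on Z-138 cells (Homo sapiens) for inhibition, read by luminescence and CellTiter-Glo, with a stated time of 72 h; on this read-out higher numbers stand for weaker inhibition and lower numbers for stronger inhibition. For compound 1 the result of > 60000 nM is a limit of the assay, not a number. For compound 2 the result of > 60000 nM is likewise a limit. For the measured compounds named here, compound 3 is the only one with a number, 8900 nM in this assay.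

Compound 2 and compound 1 differ in one place, (vinyl in place of prop-1-en-1-yl on a carbonyl carbon). The resulting step, a step that the two limits leave unreadable from compound 2 to compound 1, cannot be sized because the limit of > 60000 nM in this assay, at which 2 of the 3 values shown sit, covers both ends of it.

Compound 2 and compound 3 have different cores; that difference is not broken down here.

The unmeasured compound 4, `C=CC(=O)Nc1cccc(Cn2nc(-c3ccc(Oc4ccccc4)cc3)cc2C(=O)OCC)c1`, is made from compound 3 by vinyl in place of prop-1-en-1-yl on a carbonyl carbon. The place of change is the same as from compound 2 to compound 1, so this is the same change, but the earlier occurrence gives no readable size. Starting from the value of compound 3, 8900 nM, the expected step for compound 4 is a 2.0-fold lower number from compound 3 to compound 4 (0.30 log units; within the scatter), with wide uncertainty. Compound 4 is estimated at 4500 nM in this assay, between 1500 nM and 15000 nM.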

Compound 4, half-maximal inhibitory concentration: 7800 nM
For compound 4 the middle estimate is 1.7-fold (0.24 log units) below the measured one; low and high end bracket the measured number.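

In this assay, putting vinyl in place of prop-1-en-1-yl on the carbonyl carbon gives a 1.1-fold lower number from compound 3 to compound 4 (0.06 log units; within the scatter), so on the core of compound 3 the change has no effect that can be told apart from the ordinary spread of repeated measurements. The same change on the core of compound 2 cannot be sized, because compound 2 and compound 1 both rest on a limit of the assay rather than a number: the limit of > 60000 nM in this assay, at which 2 of the 4 values shown sit. This leaves a single readable case, which shows that the change made no measurable difference on one core but cannot show whether it behaves the same way on the other.

The compounds shown leave open what other groups on this carbonyl carbon would do, such as a longer chain or a chain carrying an amine. As far as these compounds go, with only vinyl and prop-1-en-1-yl in hand, it also remains unknown whether any group at this place can shift the result beyond the scatter.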